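This account rests on a few compounds, and the source may have more. Where it says the series, first, only, none or still open, it means among the compounds named here.

Measured in a functional assay on NCI-H460 cells (Homo sapiens) for inhibition, read by MTT assay, with a stated time of 24 h, tested at 0.1 ug/mL; a lower number here means less inhibition of growth, a higher number more inhibition of growth at the concentration tested:
- compound 1 `O=C(O)CCCCC(CCSC(=O)c1ccccc1)SC(=O)c1ccccc1` gives "not active" (no number reported)
- compound 2 `O=C(CCCCC1CCSS1)NO` gives 3.9%
- compound 3 `O=C(CCCCC1CCSS1)Nc1ccccn1` gives 2.61%

Going by the values given here, compound 3, at 2.61% in this assay, lies within the scatter of compound 2, the only other compound with a number, while compound 1 has none. The next compound, compound 4 `O=C(CCCCC1CCSS1)Nc1ccc(Br)cn1`, carries one change from compound 3: bromo in place of hydrogen on an aromatic carbon, with bromo in place of hydrogen on an aromatic carbon.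

Among the compounds with values here, only one measured step exists in this set, a number 1.3 percentage points lower from compound 2 to compound 3 (within the scatter), and it concerns the group on the amide-type nitrogen, not the ring carbon. Within the data shown here, no measurement yet shows what bromo does here, so the evidence is thin. That single small step gives no ground to expect a large one, so no change beyond the scatter is expected in this assay. The estimated step is a number 2.4 percentage points higher from compound 3 to compound 4 (within the scatter), which would stay within the scatter. For compound 4 the expected value is 5%, with an estimated range from 0% to 15% in this read-out.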

Compound 4, percent growth inhibition at one concentration: 9%
Compound 4: the middle estimate sits 4 percentage points below what was measured; measured number inside the range.
By their numbers in this assay, from the lowest: compounds 3, 2 and 4 (each within the scatter of the next).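

Bromo in place of hydrogen on an aromatic carbon, two atoms from the ring nitrogen, gives a number 6.4 percentage points higher from compound 3 to compound 4 (within the scatter) in this assay. This is the first step shown at a ring carbon rather than on the amide-type nitrogen, and it shows that this position accepts a bromo without the read-out leaving the scatter, as was also the case for the step at the nitrogen. No measured evidence here bears on the size of this step.

The compounds shown leave open whether a chloro group, a methoxy group or an amine at the same ring carbon would leave the read-out within the scatter. They also leave open whether bromo at another carbon of the ring would give a step beyond it.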